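A Fluorine Added to the Pyridine of Compound 3

The source may report more compounds than this note shows. Statements on the series, on what has been measured and on what is new or still open speak of the compounds shown alone.

Three compounds have been measured in an in vitro assay on HEK385-7 cells for displacement of a labelled ligand from prostaglandin D2 receptor 2 (Homo sapiens); on this read-out higher numbers stand for weaker inhibition and lower numbers for stronger inhibition:

compound 1, `N#Cc1ccc(-c2nc(C(c3ccc(F)cc3)c3ccc(F)cc3)sc2CC(=O)O)cc1`: 150 nM
compound 2, `O=C(O)Cc1sc(C(c2ccc(F)cc2)c2ccc(F)cc2)nc1-c1ccoc1`: 14 nM
compound 3, `O=C(O)Cc1sc(C(c2ccc(F)cc2)c2ccc(F)cc2)nc1-c1ccncc1`: 5.3 nM

Compound 3 gives the lowest number of the three, with compound 2 nearest and compound 1 furthest. The three compounds share one core and differ only in the aromatic group on it. The steps between them are all beyond the scatter: an 11-fold lower number from compound 1 to compound 2 (1.03 log units; beyond the scatter), a 28-fold lower number from compound 1 to compound 3 (1.45 log units; beyond the scatter), and a 2.6-fold lower number from compound 2 to compound 3 (0.42 log units; beyond the scatter).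

Compound 4, `O=C(O)Cc1sc(C(c2ccc(F)cc2)c2ccc(F)cc2)nc1-c1ccnc(F)c1`, keeps the pyridin-4-yl of compound 3 and differs from it by fluoro in place of hydrogen on an aromatic carbon, on an aromatic carbon of the six-membered aromatic ring with one nitrogen, next to the ring nitrogen and meta to a large group; read one bond further out, pyridin-4-yl becomes 2-fluoropyridin-4-yl.

For the measured compounds named here, none of the measured steps is of this kind: each of them exchanges the whole aromatic group, whereas here a single fluorine is added to a group that stays. The measured steps therefore give no direct guide, and a change much smaller than any of them is expected, most likely none beyond the scatter. Compound 4 is estimated at 5.5 nM, with a range from 2 nM to 16 nM. The expected step is a 1.0-fold higher number from compound 3 to compound 4 (0.02 log units; within the scatter).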

Compound 4, half-maximal inhibitory concentration: 0.48 nM
For compound 4 the middle estimate is 11-fold (1.06 log units) above the measured one; measured number below the stated range.
By their numbers in this assay, from the lowest: compound 4; then compound 3; then compound 2; then compound 1.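

In this assay the addition of one fluorine, on the carbon next to the ring nitrogen of the pyridine, moves the number by about as much as replacing the whole 4-cyanophenyl group with furan-3-yl (an 11-fold lower number from compound 3 to compound 4 (1.04 log units; beyond the scatter) against an 11-fold lower number from compound 1 to compound 2 (1.03 log units; beyond the scatter)). The earlier compounds shown here showed only that the choice of aromatic group matters, whereas this step shows that the number also depends strongly on a single atom within the group that gave the lowest value so far, and the 2-fluoropyridin-4-yl group now stands well clear of the other two aromatic groups (a 29-fold lower number from compound 2 to compound 4 (1.46 log units; beyond the scatter) and a 310-fold lower number from compound 1 to compound 4 (2.49 log units; beyond the scatter)). Nothing measured here accounts for why so small a change has so large an effect.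

The compounds shown leave open whether this carbon favours fluoro alone, or whether a chloro, methyl or methoxy group there would give a similar number. They also leave open whether a fluorine on another carbon of the pyridine would do the same, or whether this gain is tied to that one place.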